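Triazine series: benzhydryl to benzyl on the piperazine nitrogen

The source may hold more compounds than are shown below. What is called first, only, known or untested is meant among the compounds shown, and "the series" means these compounds.

Measured so far:
- compound 1 `CN1CCN(c2nc(Nc3ccc(C#N)c(C(F)(F)F)c3)nc(Oc3ccnc4ccccc34)n2)CC1`: in a functional assay on DU-145 cells (Homo sapiens) for cytotoxicity, read by sulforhodamine B assay, with a stated time of 48 h (a lower number here means a stronger inhibitor of growth, a higher number a weaker inhibitor of growth), compound 1 gives > 100000 nM, a limit of the assay.
- compound 2 `N#Cc1ccc(Nc2nc(Oc3ccnc4ccccc34)nc(N3CCN(C(c4ccccc4)c4ccccc4)CC3)n2)cc1C(F)(F)F`: in this assay compound 2 gives > 100000 nM, a limit of the assay.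

Compound 2 stands at the limit of this assay, and so does compound 1, as the limit of > 100000 nM in this assay, at which 2 of the 2 values shown sit, shows. For the measured compounds named here, neither value is a number, so no step between the two measured compounds can be given and nothing is known about how large a change in the piperazine substituent moves growth inhibition within this set.

Compound 3 `N#Cc1ccc(Nc2nc(Oc3ccnc4ccccc34)nc(N3CCN(Cc4ccccc4)CC3)n2)cc1C(F)(F)F` is the next compound in this assay. It differs from compound 2 by hydrogen in place of phenyl on a saturated chain carbon bound to an amine nitrogen in a ring and an aromatic carbon. With both neighbours at the limit, the expected step that the limit leaves unreadable from compound 2 to compound 3 is none beyond the scatter, in no particular direction. Compound 3 is expected to give about 150000 nM in this assay, within a range of 40000 nM to 600000 nM, most likely again reported as a limit.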

Compound 3, concentration for total growth inhibition: > 100000 nM
Compound 3 gave a limit, no number (the forecaster's own chance of this, stated with the estimate: 80%); the middle value is on the limit's open side.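

The steps from compound 2 to compound 3 and from compound 1 to compound 3 cannot be read, as each of the three compounds gives a limit of this assay and not a number: the limit of > 100000 nM in this assay, at which 3 of the 3 values shown sit.

The compounds shown leave open whether any substituent on the piperazine nitrogen brings growth inhibition into the readable range of this assay.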